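The source may report more compounds than this note shows. Statements on the series, on what has been measured and on what is new or still open speak of the compounds shown alone.

Three compounds have a reading in an ADME assay on L6 cells (Rattus norvegicus) for cytotoxicity, read by resazurin assay, with a stated time of 72 h (a higher number here means a weaker inhibitor, a lower number a stronger inhibitor), so far. Compound 1 `COc1ccc2cc(C3=CN4CCC3CC4)ccc2c1` gives 98800 nM there, and compound 3 `C1=C(c2ccc(OCc3ccccc3)cc2)C2CCN1CC2` gives 47200 nM there. Compound 2 `C(=C1/CN2CCC1CC2)\c1ccc(C2OCCO2)cc1` stands highest of the three at 239000 nM and its gaps to both others lie beyond the usual scatter. Compound 4 `C(=C1\CN2CCC1CC2)\c1ccc(C2OCCO2)cc1` has not yet been measured. Among the measured compounds shown here, it has the same atoms and bonds as compound 2, and the only change is in stereo (the two compounds have the same atoms and bonds; at least one stereo element is drawn with a configuration in one of them and without one in the other: 1 of 3 stereo elements differ; a double bond is drawn E in compound 2 and Z in compound 4): a double bond is drawn E in compound 2 and Z in compound 4. For the measured compounds named here, no measured pair here shows what such a switch does, so no step beyond the scatter is expected in this assay for this pair. Compound 2 at 239000 nM tops the three, so a slight lean toward a lower number is expected. The estimated change is a 1.3-fold lower number from compound 2 to compound 4 (0.10 log units; within the scatter) and it stays within the scatter. The estimate for compound 4 is 190000 nM with 90000 nM to 400000 nM as its expected range.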

Compound 4, half-maximal inhibitory concentration: 136000 nM
Estimate against measurement, compound 4: 1.4-fold (0.15 log units) above, within the range that was stated.
By their numbers in this assay, from the lowest: compound 3; then compounds 1, 4 and 2 (each within the scatter of the next, the first and the last beyond it).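

In this assay, among the compounds shown here, the only pair that differs in stereo alone gives a 1.8-fold lower number from compound 2 to compound 4 (0.24 log units; within the scatter). Moving this double bond from E to Z therefore leaves the reading within the usual scatter, so this geometry does not separate the two compounds in this cytotoxicity read-out, something the earlier compounds, with no such pair among them, could not show. The reading of this single switch carries one caution: the fact that one of compounds 2 and 4 is drawn with a defined configuration and the other without, at the place where they differ.

What the compounds shown leave open is whether this holds on other substituted versions of the shared core, for example with an amine or a carboxylic acid in place of the substituent that this pair carries. They also leave open whether the same E to Z switch would stay within the scatter in any assay other than this assay.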